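Chlorophenyl in Place of Methylphenyl: Expected Liver-Cell Toxicity

This account rests on a few compounds, and the source may have more. Where it says the series, first, only, none or still open, it means among the compounds named here.

Three close analogues have been tested in an ADME assay on L02 cells (Homo sapiens) for cytotoxicity, read by MTT assay, with a stated time of 24 h; on this read-out higher numbers stand for lower toxicity in this test and lower numbers for higher toxicity in this test. Compound 3 `Cc1cccc(-n2cc(-c3ccc(NS(=O)(=O)c4c[nH]c(=O)[nH]c4=O)cc3)nn2)c1` gives 39000 nM, the second highest of the three numbers. Compound 1 `Cc1ccccc1-n1cc(-c2ccccc2NS(=O)(=O)c2c[nH]c(=O)[nH]c2=O)nn1` gives 56600 nM, which sits within the scatter of compound 3. Compound 2 `O=c1[nH]cc(S(=O)(=O)Nc2cccc(-c3cn(-c4cccc(Cl)c4)nn3)c2)c(=O)[nH]1` gives 8330 nM, a lower number that lies beyond the scatter, so compound 2 is the more toxic of that pair. Compound 4 `O=c1[nH]cc(S(=O)(=O)Nc2ccc(-c3cn(-c4ccccc4Cl)nn3)cc2)c(=O)[nH]1` has not been measured; it differs from compound 3 by 2-chlorophenyl in place of 3-methylphenyl on an aromatic nitrogen. Within the data shown here, no pair of measured compounds isolates this change, so only a modest shift is expected. For compound 4 the expected step is a 1.8-fold lower number from compound 3 to compound 4 (0.25 log units; within the scatter). Compound 4 is estimated at 22000 nM, with a range from 6000 nM to 70000 nM.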

Compound 4, half-maximal cytotoxic concentration: 19300 nM
Estimate against measurement, compound 4: 1.1-fold (0.06 log units) above; low and high end bracket the measured number.
By their numbers in this assay, from the lowest: compound 2; then compound 4; then compounds 3 and 1 (each within the scatter of the next).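

In this assay, 2-chlorophenyl in place of 3-methylphenyl on the aromatic nitrogen gives a 2.0-fold lower number from compound 3 to compound 4 (0.31 log units; beyond the scatter). Among these compounds, this is the first step at this position that isolates one change, and it shows that a modest move toward higher toxicity in this test can come from this swap alone. No measurement on hand explains the shift.

Going by these compounds, the step changes both the group on the phenyl ring and its place on that ring, so which of the two matters remains open. On these data alone, the effect of an amine or a carboxylic acid on that ring also remains open.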